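A few compounds are considered here, and "the series" means these few. Any claim that something is new, unique, unknown or untested is made for them only; others in the source may bear on it.

Measured so far in a functional assay on HT-29 cells (Homo sapiens) for cytotoxicity, read by MTT assay, with a stated time of 48 h; on this read-out higher numbers stand for weaker inhibition and lower numbers for stronger inhibition:
- compound 1 (`COc1cc(C(=O)c2cn(-c3cccc(N)c3)cc2-c2ccccc2F)cc(OC)c1OC`) gives 56 nM
- compound 2 (`COc1cc(C(=O)c2cn(-c3cccc(N)c3)cc2-c2ccccc2[N+](=O)[O-])cc(OC)c1OC`) gives 51 nM

On these numbers, compound 2 stands level with compound 1, as their two values lie within the scatter of each other. Still unmeasured is compound 3 (`COc1cc(C(=O)c2cn(-c3cccc(N)c3)cc2-c2ccc(N)cc2)cc(OC)c1OC`), which has 4-aminophenyl in place of 2-nitrophenyl on an aromatic carbon of a five-membered aromatic ring with 1 nitrogen (4-aminophenyl in place of 2-nitrophenyl on an aromatic carbon).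

Going by the values given here, only one measured step bears on this change. With nitro in place of fluoro on an aromatic carbon, the data show a 1.1-fold lower number from compound 1 to compound 2 (0.04 log units; within the scatter) in this series. Among the compounds with values here, that single small step offers limited guidance, since no measured compound carries 4-aminophenyl at this place and the data give no direction for such a swap. The expected outcome is therefore no shift beyond the scatter, held with wide uncertainty. The estimated step is a 1.2-fold higher number from compound 2 to compound 3 (0.07 log units; within the scatter) and its direction is not firmly supported. In this assay the estimate for compound 3 is 60 nM with an expected range from 15 nM to 250 nM for the measurement to come.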

Compound 3, half-maximal inhibitory concentration: 51 nM
Estimate against measurement, compound 3: 1.2-fold (0.07 log units) above; low and high end bracket the measured number.
By their numbers in this assay, from the lowest: compounds 2, 3 and 1 (each within the scatter of the next).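

In this assay, 4-aminophenyl in place of 2-nitrophenyl on this aromatic carbon of the five-membered ring gives no change at the digits printed from compound 2 to compound 3 (within the scatter) in the comparison, while 4-aminophenyl in place of 2-fluorophenyl gives a 1.1-fold lower number from compound 1 to compound 3 (0.04 log units; within the scatter) at the same place. The earlier compounds shown here had compared only 2-fluorophenyl with 2-nitrophenyl, whereas these steps extend the comparison to a phenyl group with an amine at its 4-position, and all three compounds lie within the scatter of one another in this cell read-out. So, among these three groups, neither the swap of the group on the phenyl ring nor the loss of the nitro oxygens separates the compounds on this measure, and no information is available here that could account for this.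

The compounds shown leave open whether a plain phenyl, a 4-carboxyphenyl or a small alkyl chain at this place would also stay within the scatter of these values. They also leave open whether the 3-aminophenyl group on the ring nitrogen, replaced by a plain phenyl or a methyl group, would shift the number in this assay while 4-aminophenyl stays in place.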